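The source may report more compounds than this note shows. Statements on the series, on what has been measured and on what is new or still open speak of the compounds shown alone.

Of the compounds shown here, three have so far been measured in a functional assay on KB cells (Homo sapiens) for antiproliferative activity, read by sulforhodamine B assay, with a stated time of 72 h; a lower number here means a stronger inhibitor of growth, a higher number a weaker inhibitor of growth. Compound 1 `Cc1cc(=O)oc2cc(SCc3cccnc3)ccc12` reaches only the limit of the assay, giving > 35200 nM. Compound 2 `Cc1cc(=O)oc2cc(SCc3ccncc3)ccc12` likewise returns only a limit, > 35200 nM. The step that the two limits leave unreadable from compound 1 to compound 2 can therefore not be read from these two entries. For the measured compounds named here, compound 3 `COC(=O)c1cccc(CSc2ccc3c(C)cc(=O)oc3c2)c1` is the single member with a real number: in this assay compound 3 gives 2060 nM, and it stands alone on that count, since the limit of > 35200 nM in this assay, at which 2 of the 3 values shown sit, covers the two remaining entries.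

Compound 4 `Cc1cccc(CSc2ccc3c(C)cc(=O)oc3c2)c1` has not yet been measured. It differs from compound 3 by methyl in place of methoxycarbonyl on an aromatic carbon of a six-membered aromatic ring of carbon only, meta to a large group. Going by the values given here, no measured step bears on this change: the one step that exists is unreadable and concerns a different part of the molecule. The expectation therefore rests on compound 3 alone, and the direction of the step is open, so no change beyond the scatter is assumed. Compound 4 is expected to give 4000 nM, with a range from 1000 nM to 20000 nM. That estimate corresponds to an expected step of a 1.9-fold higher number from compound 3 to compound 4 (0.29 log units; within the scatter).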

Compound 4, concentration for 50% growth inhibition: > 33700 nM
Compound 4: only a limit was reported (the forecaster's own chance of this, stated with the estimate: 25%); at least 8.4-fold (0.92 log units) between middle value and limit.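

In this assay, for the compounds shown here, the earlier compounds offered no readable step, and this change gives the first one: on an aromatic carbon meta to a large group, methyl in place of methoxycarbonyl gives an at least 16-fold higher number from compound 3 to compound 4 (1.21 log units; beyond the scatter). Going by these compounds alone, the group at this place therefore makes a difference, and compound 3 remains the only member with a real number. The result for compound 4 is itself only a limit of the assay, not a number: the limit of > 33700 nM in this assay, at which 1 of the 4 values shown sits.

The steps to compound 4 from compound 1 and from compound 2 join limit to limit and cannot be read, so the compounds shown do not rank the 3-methylphenyl, pyridin-3-yl and pyridin-4-yl side chains against one another. On these data alone, it also remains open which part of methoxycarbonyl carries the step, and whether a carboxylic acid, a primary amide or an acetyl group at the same place would keep a measurable growth inhibition, or whether a longer chain between the sulfur and the ring would alter the picture.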